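Chlorophenyl for methoxyphenyl on the ring nitrogen

A few compounds are considered here, and "the series" means these few. Any claim that something is new, unique, unknown or untested is made for them only; others in the source may bear on it.

In a functional assay on MCF7 cells (Homo sapiens) for cytotoxicity, read by MTT assay, with a stated time of 24 h (on this read-out lower numbers stand for stronger inhibition and higher numbers for weaker inhibition), compound 1 `CN1CCN(CCCSc2nc3ccccc3[nH]2)CC1` gives 77900 nM and compound 2 `COc1ccc(N2CCN(CCCSc3nc4ccccc4[nH]3)CC2)cc1` gives 6840 nM. For the measured compounds named here, the single change between them, 4-methoxyphenyl in place of methyl on an amine nitrogen in a ring, brought an 11-fold lower number from compound 1 to compound 2 (1.06 log units; beyond the scatter), so compound 2 stands at the lower of the two numbers measured so far. Compound 3 `Clc1cccc(N2CCN(CCCSc3nc4ccccc4[nH]3)CC2)c1` differs from compound 2 in one place: 3-chlorophenyl in place of 4-methoxyphenyl on an amine nitrogen in a ring. Going by the values given here, only the step from compound 1 to compound 2 bears on this, and it concerned the exchange of methyl for an aryl group rather than one aryl group for another; nothing measured so far shows how one substituted phenyl compares with another at this position. Since an aromatic ring remains at the same place, compound 3 is expected to stay near that value, with an expected step of a 1.2-fold lower number from compound 2 to compound 3 (0.09 log units; within the scatter) in this assay that may not clear the scatter. Compound 3 is therefore estimated at 5500 nM, within a range of 2000 nM to 15000 nM.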

Compound 3, half-maximal inhibitory concentration: 54600 nM
Estimate against measurement, compound 3: 9.9-fold (1.00 log units) below, outside the stated range (above it).
By their numbers in this assay, from the lowest: compound 2; then compounds 3 and 1 (each within the scatter of the next).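

The aryl group on this ring nitrogen does not by itself bring the gain seen earlier: in this assay, 3-chlorophenyl in place of 4-methoxyphenyl gave an 8.0-fold higher number from compound 2 to compound 3 (0.90 log units; beyond the scatter). Set against methyl, 3-chlorophenyl gave a 1.4-fold lower number from compound 1 to compound 3 (0.15 log units; within the scatter), so an aromatic ring at this place is not enough, and which substituted phenyl stands there decides whether the number falls. Nothing measured on these compounds accounts for the difference between the two phenyl groups.

The two phenyl groups differ both in the substituent and in where it stands, so the compounds shown do not separate these two changes. From the compounds shown here alone, whether 4-chlorophenyl, 3-methoxyphenyl or plain phenyl would stand nearer compound 2 or compound 3 remains open.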